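Swapping Fluoro for Methoxy on the Pendant Phenyl Ring

The compounds below may be only part of what the source reports. "The series", "measured", "known", "first", "only" and "open" are said of these compounds alone.

For the measured compounds named here, in an in vitro assay on COS-7 cells for displacement of a labelled ligand from prostaglandin D2 receptor 2 (Homo sapiens) (a higher number here means a weaker inhibitor, a lower number a stronger inhibitor), compound 2 `O=C(O)Cc1sc(Nc2ccccc2)nc1-c1ccc(F)cc1` gives 650 nM, the highest of the two numbers so far. Its neighbour compound 1 `O=C(O)Cc1sc(Nc2ccccc2)nc1-c1ccccc1` gives 350 nM, and the step of a 1.9-fold higher number from compound 1 to compound 2 (0.27 log units; within the scatter) lies within the scatter. Compound 3 `COc1ccc(-c2nc(Nc3ccccc3)sc2CC(=O)O)cc1` differs from compound 2 by methoxy in place of fluoro on an aromatic carbon, the same difference cut one bond further out reading 4-fluorophenyl to 4-methoxyphenyl. Going by the values given here, the only measured step on that ring, hydrogen to fluoro, stayed within the scatter, so no shift beyond the scatter is expected here either. For compound 3 the estimate is 500 nM, ranging from 180 nM to 1500 nM, an expected step of a 1.3-fold lower number from compound 2 to compound 3 (0.11 log units; within the scatter).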

Compound 3, half-maximal inhibitory concentration: 1900 nM
Compound 3: the middle estimate sits 3.8-fold (0.58 log units) below what was measured; measured number outside the range, above it.
By their numbers in this assay, from the lowest: compounds 1 and 2 (each within the scatter of the next); then compound 3.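

In this assay, this position is not indifferent to what it carries: methoxy gives a 2.9-fold higher number from compound 2 to compound 3 (0.47 log units; beyond the scatter) and also a 5.4-fold higher number from compound 1 to compound 3 (0.73 log units; beyond the scatter) while hydrogen and fluoro remain within the scatter of each other. For the compounds shown here, compound 3 is thus the weaker inhibitor against both neighbours, the first change here to clear the scatter. No measurement given here accounts for this drop.

As far as these compounds go, whether the oxygen or the added carbon matters more stays open. A hydroxyl, a methyl or an ethoxy group at this same place could help separate the two.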